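Hydroxy Pattern on the Benzyl Arm of the Shared Core

The compounds below may be only part of what the source reports. "The series", "measured", "known", "first", "only" and "open" are said of these compounds alone.

The series holds the shared core with a cyclopropyl on the ring nitrogen and varies only the benzyl arm. Compound 1 `Cc1cc(-c2c(F)cc3c(=O)c(Cc4cccc(O)c4)cn(C4CC4)c3c2F)cc(C)n1` carries 3-hydroxyphenyl; in a functional assay on P388 cells (Mus musculus) for cytotoxicity (on this read-out lower numbers stand for stronger inhibition and higher numbers for weaker inhibition), compound 1 gives 2200 nM. Compound 2 `Cc1cc(-c2c(F)cc3c(=O)c(Cc4c(O)cc(O)cc4O)cn(C4CC4)c3c2F)cc(C)n1` carries 2,4,6-trihydroxyphenyl in place of 3-hydroxyphenyl on a saturated chain carbon bound to an aromatic carbon, and in this assay compound 2 gives 470 nM. Among the compounds with values here, on these numbers compound 1 stands highest of the two, with a 4.7-fold lower number from compound 1 to compound 2 (0.67 log units; beyond the scatter) as the only measured step.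

Compound 3 `Cc1cc(-c2c(F)cc3c(=O)c(Cc4cc(O)ccc4O)cn(C4CC4)c3c2F)cc(C)n1` is not yet measured. It differs from compound 1 by hydroxy in place of hydrogen on an aromatic carbon, cut one bond further out: 3-hydroxyphenyl to 2,5-dihydroxyphenyl. Within the data shown here, the one step that bears on it is the move to compound 2, which added hydroxy groups to the same ring and gave a 4.7-fold lower number from compound 1 to compound 2 (0.67 log units; beyond the scatter). A smaller addition here is expected to give a smaller step in the same direction, so for compound 3 the step of a 2.2-fold lower number from compound 1 to compound 3 (0.34 log units; beyond the scatter) in this assay is expected. Compound 3 is estimated at 1000 nM, within 400 nM to 2500 nM.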

Compound 3, half-maximal inhibitory concentration: 360 nM
Compound 3: the middle estimate sits 2.8-fold (0.44 log units) above what was measured; measured number outside the range, below it.
By their numbers in this assay, from the lowest: compounds 3 and 2 (each within the scatter of the next); then compound 1.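

In this assay, a single hydroxy in place of hydrogen on the aromatic carbon ortho to a large group and para to a hydroxy group, turning 3-hydroxyphenyl into 2,5-dihydroxyphenyl, gives a 6.1-fold lower number from compound 1 to compound 3 (0.79 log units; beyond the scatter) and so one added hydroxy at this place is enough for a step beyond the scatter. With a 1.3-fold lower number from compound 2 to compound 3 (0.12 log units; within the scatter) the 2,5-dihydroxyphenyl and 2,4,6-trihydroxyphenyl arms cannot be told apart on this read-out, so a step of this size does not require the full trihydroxy pattern. Nothing among the data shown bears on why the added hydroxy has this effect.

Still open, going by these compounds, is whether a methoxy, an amine or a carboxylic acid at the same aromatic carbon would give a step of similar size to the hydroxy. Also open, on these data alone, are how much the hydroxy already present in compound 1 contributes to the 2,5-dihydroxyphenyl result and whether the same step holds with a group other than cyclopropyl on the ring nitrogen.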